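Replacing the 5-methyl-1H-imidazol-4-yl group of compound 2

A few compounds are considered here, and "the series" means these few. Any claim that something is new, unique, unknown or untested is made for them only; others in the source may bear on it.

Compound 1 `Cc1[nH]cnc1/C=c1\[nH]c(=O)/c(=C/c2cccc(Oc3ccc(F)cc3)c2)[nH]c1=O`: 47.6 nM
Compound 2 `Cc1[nH]cnc1/C=c1\[nH]c(=O)/c(=C/c2cccc(C(=O)c3ccc(F)cc3)c2)[nH]c1=O`: 15.9 nM
Compound 3 `O=c1[nH]/c(=C\c2ccc(Cl)o2)c(=O)[nH]/c1=C\c1cccc(Oc2ccc(F)cc2)c1`: 180 nM

All three values come from a functional assay on NCI-H460 cells (Homo sapiens) for cytotoxicity, read by MTT assay, with a stated time of 72 h; a lower number here means a stronger inhibitor, a higher number a weaker inhibitor. Compound 2 has the lowest number of the three, and its gaps to both other compounds lie beyond the scatter. Compound 4 `COCc1ccc(/C=c2\[nH]c(=O)/c(=C/c3cccc(C(=O)c4ccc(F)cc4)c3)[nH]c2=O)o1` has not yet been measured. It departs from compound 2 in one place: 5-(methoxymethyl)furan-2-yl in place of 5-methyl-1H-imidazol-4-yl on a double-bonded chain carbon bound to an aromatic carbon, with 5-(methoxymethyl)furan-2-yl in place of 5-methyl-1H-imidazol-4-yl on a double-bonded chain carbon bound to an aromatic carbon. For the measured compounds named here, the closest precedent is a 3.8-fold higher number from compound 1 to compound 3 (0.58 log units; beyond the scatter), where 5-chlorofuran-2-yl replaced the same group. The other measured step, a 3.0-fold lower number from compound 1 to compound 2 (0.48 log units; beyond the scatter), concerns the (4-fluorophenyl)carbonyl group, which compound 4 keeps from compound 2, so it bears on this change only indirectly. Going by the values given here, no measured compound carries the 5-(methoxymethyl)furan-2-yl group, so the precedent is imperfect. A modest rise of similar size is therefore expected. The estimated change is a 3.8-fold higher number from compound 2 to compound 4 (0.58 log units; beyond the scatter). For compound 4 the expected value is 60 nM, with an estimated range from 20 nM to 190 nM.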

Compound 4, half-maximal inhibitory concentration: 2.9 nM
Compound 4: the middle estimate sits 21-fold (1.32 log units) above what was measured, outside the stated range (below it).
By their numbers in this assay, from the lowest: compound 4; then compound 2; then compound 1; then compound 3.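

With the (4-fluorophenyl)carbonyl group held in place, this double-bonded chain position accepts 5-(methoxymethyl)furan-2-yl in place of 5-methyl-1H-imidazol-4-yl, and this assay records a 5.5-fold lower number from compound 2 to compound 4 (0.74 log units; beyond the scatter). The entering group counts 0 hydrogen-bond donors against 1 for the group that leaves, so a low number at this position does not depend on a donor in this group, and a furan here need not raise the number as it did in a 3.8-fold higher number from compound 1 to compound 3 (0.58 log units; beyond the scatter). The data shown offer no measured basis for explaining this drop.

The two furan steps differ in both the furan substituent and the group on the other side of the core, so the compounds shown cannot separate those contributions. Going by these compounds, whether an aminomethyl group or a carboxylic acid on the furan would keep the low number also stays open.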